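The compounds below may be only part of what the source reports. "The series", "measured", "known", "first", "only" and "open" are said of these compounds alone.

Of the compounds shown here, three have been measured in a physicochemical assay for metabolic stability, read by HPLC; on this read-out lower numbers stand for a shorter-lived compound and higher numbers for a longer-lived compound. Compound 1 `O=c1ccn([C@H]2CC[C@@H](COP(=O)(O)Oc3ccccc3)O2)c(=O)[nH]1` gives 25.1 h. Compound 2 `Cc1cn([C@H]2C[C@H](N=[N+]=[N-])[C@@H](COP(=O)(O)Oc3ccc(Br)cc3)O2)c(=O)[nH]c1=O` gives 7.97 h, and compound 3 `Nc1ncnc2c1ncn2[C@H]1CC[C@@H](COP(=O)(O)Oc2ccccc2)O1` gives 36.1 h. Compound 2 therefore stands lowest of the three: the number for compound 1 is higher by an amount beyond the usual scatter, and the number for compound 3 lies furthest away, also beyond the scatter. Compound 4 `Cc1cn([C@H]2C[C@H](N=[N+]=[N-])[C@@H](COP(=O)(O)Oc3ccc(Cl)cc3Cl)O2)c(=O)[nH]c1=O` has not yet been measured in this assay. It differs from compound 2 in one place only: 2,4-dichlorophenyl in place of 4-bromophenyl on an oxygen. Among the measured compounds shown here, no pair of measured compounds shows this change, so there is no measured step to lean on. The step from compound 2 to compound 4 is expected to be small, with a 1.1-fold higher number from compound 2 to compound 4 (0.05 log units; within the scatter) lying within the scatter and no firm direction to be claimed. Compound 4 is therefore estimated to give about 9 h in this assay, with a range from 4 h to 20 h.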

Compound 4, half-life: 3.03 h
Compound 4: the middle estimate sits 3.0-fold (0.47 log units) above what was measured, and the stated range ends above it.
By their numbers in this assay, from the lowest: compound 4; then compound 2; then compounds 1 and 3 (each within the scatter of the next).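

In this assay, putting 2,4-dichlorophenyl in place of 4-bromophenyl on an oxygen whose other neighbour is phosphorus gives a 2.6-fold lower number from compound 2 to compound 4 (0.42 log units; beyond the scatter) and so moves the number beyond the scatter. Both groups hold one six-membered aromatic ring of carbon only and differ in the halogens they carry, so a change in the halogens on that ring alone is enough to shift the half-life at this place. Nothing available here bears on why the number moved.

This single pair cannot separate the loss of the bromine from the arrival of the two chlorines, and a 4-chlorophenyl group on the same core would help to tell them apart. As far as these compounds go, whether a ring carrying a methoxy group or an amine instead of a halogen would shift the number in the same way also stays open.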